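A few compounds are considered here, and "the series" means these few. Any claim that something is new, unique, unknown or untested is made for them only; others in the source may bear on it.

Measured so far:
compound 1, `COC(=O)[C@@H]1CN(C)CC[C@@H]1c1ccc2ccccc2c1`, 21 nM in an assay on a subcellular fraction from brain for inhibition of sodium-dependent dopamine transporter (Rattus norvegicus); a higher number here means a weaker inhibitor, a lower number a stronger inhibitor
compound 2, `COC(=O)[C@H]1CN(C)CC[C@@H]1c1ccc2ccccc2c1`, 947 nM in this assay

Compound 2 holds the highest of the two numbers in this assay; its nearest neighbour is compound 1, separated by a 45-fold higher number from compound 1 to compound 2 (1.65 log units; beyond the scatter). That step rests on (the fact that compounds 1 and 2 differ only in the configuration as drawn), and nothing else in the series speaks to it.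

Compound 3, `COC(=O)[C@H]1CN(C)CC[C@H]1c1ccc2ccccc2c1`, has not yet been measured in this assay. It differs from compound 2 as follows: the two compounds have the same atoms and bonds and differ only in configuration as drawn: 1 of 2 stereo elements differ; a stereocentre at a saturated ring carbon is drawn S in compound 2 and R in compound 3. Relative to compound 1, compound 3 is therefore inverted at both stereo elements, its mirror image. For the measured compounds named here, the only measured step, from compound 1 to compound 2, shows that a single inversion at a ring carbon changes the number greatly. Which way a second inversion moves it cannot be read from two compounds, so the expected step of a 2.4-fold lower number from compound 2 to compound 3 (0.37 log units; beyond the scatter) for compound 3 is given with a wide margin. For compound 3 the estimate in this assay is 400 nM, within 40 nM to 4000 nM.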

Compound 3, inhibition constant: 271 nM
Estimate against measurement, compound 3: 1.5-fold (0.17 log units) above, and the stated range covers the measured number.
By their numbers in this assay, from the lowest: compound 1; then compound 3; then compound 2.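

In this assay, a second inversion does not push the number further from compound 1 but brings it partly back (a 3.5-fold lower number from compound 2 to compound 3 (0.54 log units; beyond the scatter)). The effects of the two stereo elements are therefore not simply additive across these three compounds. Compound 3 still stands well apart from its mirror image (a 13-fold higher number from compound 1 to compound 3 (1.11 log units; beyond the scatter)), so configuration alone separates the pair, and neither inversion tried here matches compound 1.

From the compounds shown here alone, the mirror image of compound 2 would complete the set of stereoisomers, and its place in this order remains open. Going by these compounds, it is also open whether the same order of configurations would hold with a carboxylic acid or an amide in place of the ester, or with a secondary amine in place of the tertiary one.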